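Chloro-to-amino swap at the benzene of the fused core

The source may report more compounds than this note shows. Statements on the series, on what has been measured and on what is new or still open speak of the compounds shown alone.

Measured so far in a functional assay on K562 cells (Homo sapiens) for antiproliferative activity, read by sulforhodamine B assay, with a stated time of 48 h; on this read-out lower numbers stand for stronger inhibition of growth and higher numbers for weaker inhibition of growth:
- compound 1 `Nc1nn(C(=O)Nc2ccc(Cc3ccccc3)cc2)c2ccccc12`: 33800 nM
- compound 2 `Nc1nn(C(=O)Nc2ccc(Cc3ccccc3)cc2)c2ccc(Cl)cc12`: 14700 nM

Compound 2 stands lower of the two numbers measured; the step of a 2.3-fold lower number from compound 1 to compound 2 (0.36 log units; beyond the scatter) puts it beyond the scatter from compound 1, so on this read-out compound 2 is the stronger growth inhibitor of the pair.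

Compound 3 `Nc1ccc2c(c1)c(N)nn2C(=O)Nc1ccc(Cc2ccccc2)cc1` has not been measured. Against compound 2 the change is amino in place of chloro on an aromatic carbon. Among the compounds with values here, the only measured step, a 2.3-fold lower number from compound 1 to compound 2 (0.36 log units; beyond the scatter), concerns the same aromatic carbon but a different exchange, hydrogen for chloro, not chloro for amino. Within the data shown here, it shows the position is sensitive, but it gives no direction for an amino group; no measured pair separates chloro from amino. The expectation in this assay therefore leans toward a modest loss relative to compound 2, with a wide range that keeps a value near compound 2 or back near compound 1 within reach.

The estimate for compound 3 is 25000 nM (range 9000 nM to 70000 nM), which is expected to amount to a 1.7-fold higher number from compound 2 to compound 3 (0.23 log units; within the scatter).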

Compound 3, concentration for total growth inhibition: 11400 nM
Compound 3: the middle estimate sits 2.2-fold (0.34 log units) above what was measured; the range from low to high includes it.
By their numbers in this assay, from the lowest: compounds 3 and 2 (each within the scatter of the next); then compound 1.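

In this assay, amino in place of chloro on this aromatic carbon gives a 1.3-fold lower number from compound 2 to compound 3 (0.11 log units; within the scatter), so this first direct pairing of the two groups does not separate them. Amino in place of hydrogen at the same carbon gives a 3.0-fold lower number from compound 1 to compound 3 (0.47 log units; beyond the scatter), which shows that the step away from hydrogen seen earlier is not confined to chloro: two different groups at this carbon now give lower numbers than compound 1, beyond the scatter in both cases. No available evidence explains why chloro and amino cannot be told apart here.

The compounds shown leave open how far this holds for other groups on the same carbon, such as methoxy, a nitrile, a carboxylic acid or an acetamide, and whether any of them would move the number beyond the scatter from compound 2 and compound 3. They also leave open whether amino and chloro would remain inseparable if the rest of the molecule changed, since all three compounds share everything except the group on this one aromatic carbon.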